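The source may report more compounds than this note shows. Statements on the series, on what has been measured and on what is new or still open speak of the compounds shown alone.

Of the compounds shown here, three sharing one core have been measured in a functional assay on HT-29 cells (Homo sapiens) for antiproliferative activity, read by sulforhodamine B assay, with a stated time of 48 h; on this read-out higher numbers stand for weaker inhibition and lower numbers for stronger inhibition. Compound 1 `CCCN1CCN(c2ccc(S(=O)(=O)Oc3ccccc3CC)cc2)C1=O`, with a 2-ethylphenyl on the oxygen bound to the sulfonyl sulfur, gives > 100000 nM, which is a limit of the assay. Compound 2 `CCCN1CCN(c2ccc(S(=O)(=O)Oc3ccccc3OC)cc2)C1=O`, with methoxy in place of ethyl, gives > 100000 nM, which is also a limit. Going by the values given here, compound 3 `CCCN1CCN(c2ccc(S(=O)(=O)Oc3c(Cl)cc(Cl)cc3Cl)cc2)C1=O`, carrying 2,4,6-trichlorophenyl, gives 56000 nM, the only actual number so far.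

The next structure is compound 4 `CCCN1CCN(c2ccc(S(=O)(=O)Oc3cccc(F)c3)cc2)C1=O`, and the change is 3-fluorophenyl in place of 2,4,6-trichlorophenyl on an oxygen. The group on that oxygen remains a six-membered aromatic ring of carbon only, but its three chlorine atoms are gone and one fluorine enters.

Among the compounds with values here, two measured steps bear on this, both introducing the 2,4,6-trichlorophenyl group: an at least 1.7-fold lower number from compound 1 to compound 3 (0.25 log units; that floor lies within the scatter) and an at least 1.7-fold lower number from compound 2 to compound 3 (0.25 log units; that floor lies within the scatter). Neither floor lies beyond the scatter, so they offer only weak guidance. Even so, the two compounds without this group, compound 1 and compound 2, both stand at the limit, so a move towards weaker inhibition is expected in this assay. The expected change is a 1.6-fold higher number from compound 3 to compound 4 (0.21 log units; within the scatter). For compound 4 the estimated value is 90000 nM, with an expected range of 35000 nM to 200000 nM.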

Compound 4, half-maximal inhibitory concentration: 18000 nM
The estimate for compound 4 lay 5.0-fold (0.70 log units) above the measured number, outside the stated range (below it).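

In this assay, compound 4 shows that the 2,4,6-trichlorophenyl group is not needed on the oxygen bound to the sulfonyl sulfur for a measurable number, since the single-fluorine 3-fluorophenyl group gives stronger inhibition, with a 3.1-fold lower number from compound 3 to compound 4 (0.49 log units; beyond the scatter). Going by these compounds alone, this is the first change at this position whose size is read as beyond the scatter, and the same group also outdoes the two groups that had left the earlier compounds at the limit, with an at least 5.5-fold lower number from compound 2 to compound 4 (0.74 log units; beyond the scatter) and with an at least 5.5-fold lower number from compound 1 to compound 4 (0.74 log units; beyond the scatter). Those two steps are floors and their true size cannot be read, because the values of compound 1 and compound 2 are limits: the limit of > 100000 nM in this assay, at which 2 of the 4 values shown sit.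

The step to compound 4 removes three chlorine atoms, adds one fluorine and alters the pattern on the ring all at once, so the compounds shown do not separate the kind of halogen, the number of halogen atoms and their place. On these data alone, how a plain phenyl, or a phenyl carrying an amine or a carboxylic acid, would read on this oxygen remains open.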